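A few compounds are considered here, and "the series" means these few. Any claim that something is new, unique, unknown or untested is made for them only; others in the source may bear on it.

Series notes on the shared core with a cyclopropyl-bearing glycinamide arm and benzyl ester. In a functional assay on the whole organism (Tail, strain ICR) with Mus musculus as the target, in the tail flick test, with a stated time of 60 min, at a dose of 25 umol/kg by the oral route (a lower number here means a weaker effect, a higher number a stronger effect of the compound at the dose given), compound 1 `O=C(CN(c1nc(Cl)nc2[nH]cnc12)C1CC1)N[C@@H](CO)C(=O)OCc1ccccc1` gives 34.2%, compound 2 `C[C@@H](O)[C@H](NC(=O)CN(c1nc(Cl)nc2[nH]cnc12)C1CC1)C(=O)OCc1ccccc1` gives 29.7%, and compound 3 `N=C(N)NCCC[C@H](NC(=O)CN(c1nc(Cl)nc2[nH]cnc12)C1CC1)C(=O)OCc1ccccc1` gives 30.6%. The three numbers sit within the scatter of one another: a number 3.6 percentage points lower from compound 1 to compound 3 (within the scatter), a number 0.9 percentage points higher from compound 2 to compound 3 (within the scatter), and a number 4.5 percentage points lower from compound 1 to compound 2 (within the scatter). Compound 4 `NCCCC[C@H](NC(=O)CN(c1nc(Cl)nc2[nH]cnc12)C1CC1)C(=O)OCc1ccccc1` differs from compound 3 by a group of 2 heavy atoms (1 carbon, 1 nitrogen; no ring) in place of a group of 4 heavy atoms (1 carbon, 3 nitrogen; no ring), on a saturated chain carbon, four bonds along the chain from an amide-type nitrogen and a carbonyl carbon. The two steps that alter the same side chain, from compound 1 and from compound 2 to compound 3, both stayed within the scatter, so no step beyond the scatter is expected for this change either. The expected step is a number 0.4 percentage points higher from compound 3 to compound 4 (within the scatter). Compound 4 is thus expected to give 31% in this assay, with a range from 21% to 41%.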

Compound 4, a percentage reported as activity, at one dose (the size of the read-out at that dose, not a potency): 41.2%
For compound 4 the middle estimate is 10.2 percentage points below the measured one; measured number above the stated range.
By their numbers in this assay, from the lowest: compounds 2, 3, 1 and 4 (each within the scatter of the next, the first and the last beyond it).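

For the compounds shown here, at this side-chain position, 4-aminobutyl gives the first steps beyond the scatter: a number 10.6 percentage points higher from compound 3 to compound 4 (beyond the scatter) and a number 11.5 percentage points higher from compound 2 to compound 4 (beyond the scatter). Against the hydroxymethyl-bearing compound 1 there is no such separation, with a number 7 percentage points higher from compound 1 to compound 4 (within the scatter). The side chain can therefore shift the read-out, but only compound 2 and compound 3 go with that pattern, while compound 1 goes against it.

On these data alone, whether a shorter chain ending in an amine, a longer chain, or a carboxylic acid at this position would hold that level remains open. Nothing available explains the step to compound 4.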